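Second chloro on the core of compound 3: expected growth inhibition

The source may report more compounds than this note shows. Statements on the series, on what has been measured and on what is new or still open speak of the compounds shown alone.

Measured compounds:
compound 1 `ClCc1cccc(Cn2cnc3c(Cl)ncnc32)c1`: 3460 nM
compound 2 `ClCc1cccc(Cn2cnc3c(Cl)nc(Cl)nc32)c1`: 1990 nM
compound 3 `ClCc1ccccc1Cn1cnc2ncnc(Cl)c21`: 2290 nM

All three values come from a functional assay on Hs-578T cells (Homo sapiens) for cytotoxicity, read by sulforhodamine B assay, with a stated time of 48 h; a higher number here means a weaker inhibitor of growth, a lower number a stronger inhibitor of growth. Compound 1 and compound 3 are built from the same atoms joined differently; the difference between the two cores is not broken down here, and their values sit within the scatter of each other. From compound 1 to compound 2 the change is chloro in place of hydrogen on an aromatic carbon, and in this assay it gives a 1.7-fold lower number from compound 1 to compound 2 (0.24 log units; within the scatter).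

Compound 4 `ClCc1ccccc1Cn1cnc2nc(Cl)nc(Cl)c21` is not yet measured. It differs from compound 3 by chloro in place of hydrogen on an aromatic carbon, the same change as that from compound 1 to compound 2, at a place described in the same words. The step for compound 4 is therefore expected to be a 1.6-fold lower number from compound 3 to compound 4 (0.21 log units; within the scatter), resting on compound 1 to compound 2 giving a 1.7-fold lower number from compound 1 to compound 2 (0.24 log units; within the scatter). Compound 4 is estimated at 1400 nM, with a range from 700 nM to 2800 nM.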

Compound 4, concentration for 50% growth inhibition: 670 nM
The estimate for compound 4 lay 2.1-fold (0.32 log units) above the measured number; measured number below the stated range.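

In this assay, chloro in place of hydrogen on an aromatic carbon gives a 3.4-fold lower number from compound 3 to compound 4 (0.53 log units; beyond the scatter), a step beyond the scatter on the core of compound 3. Set beside the earlier step, the two cores do not separate: the same change on two cores in this assay, a 1.7-fold lower number (0.24 log units; within the scatter) from compound 1 to compound 2 and a 3.4-fold lower number (0.53 log units; beyond the scatter) from compound 3 to compound 4, 2.0-fold (0.29 log units) apart, within the scatter of two such steps. Among the compounds shown here, the change can therefore be carried between these two cores with no measurable difference in step size, but this does not establish a fixed step size: only two pairs are available, and the step on the core of compound 1 stays within the scatter.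

Still open, as far as these compounds go, is whether an amine or a methoxy group between two ring nitrogen atoms would give a step like that of chloro. Cores beyond these two also remain untested for this change.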